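Isopropyl for thiophen-2-yl on the amine nitrogen

The source may hold more compounds than are shown below. What is called first, only, known or untested is meant among the compounds shown, and "the series" means these compounds.

Three compounds on the shared core carry numbers in a functional assay on L1210 cells (Mus musculus) for antiproliferative activity; a lower number here means a less potent compound, a higher number a more potent compound, by a factor of ten per unit of this negative logarithm. Compound 1 `CN(/N=N/c1ccc(C(N)=O)cc1)c1cccs1` gives 2.9, the lowest of the three. Compound 3 `CN/N=N/c1nc[nH]c1C(=O)OC` gives 3.35, a number above compound 1 by more than the scatter. Compound 2 `CN(C)/N=N/c1ccc(CCCC(=O)NN)cc1` gives 3.6, the furthest above compound 1, also beyond the scatter. Going by the values given here, no pair of these differs in one place only, so no single-change step is on hand. Compound 4 `CC(C)N(C)/N=N/c1ccc(C(N)=O)cc1`, not yet measured, differs from compound 1 by isopropyl in place of thiophen-2-yl on an amine nitrogen. Nothing in the series speaks to this change, and the expected step is a number 0.20 log units higher from compound 1 to compound 4 (within the scatter). Compound 4 is estimated at 3.1, in the range 2.6 to 3.7.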

Compound 4, logarithm of the reciprocal of the active concentration, log(1/C): 3.17
Compound 4: the middle estimate sits 0.07 log units below what was measured; low and high end bracket the measured number.
By their numbers in this assay, from the lowest: compounds 1, 4, 3 and 2 (each within the scatter of the next, the first and the last beyond it).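

In this assay, the single-change step reads a number 0.27 log units higher from compound 1 to compound 4 (within the scatter). At this amine nitrogen, thiophen-2-yl and isopropyl are therefore not told apart by this read-out, so the five-membered aromatic ring is not needed to hold the number seen for compound 1. Nothing measured here accounts for this result.

Open, on these data alone, is whether a phenyl, a cyclohexyl or a longer chain on this nitrogen would separate from these two groups. Also open, as far as these compounds go, is whether the same swap gives a similar step on other cores.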